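The source may report more compounds than this note shows. Statements on the series, on what has been measured and on what is new or still open speak of the compounds shown alone.

Compound 1 `CCCCCCCCC#Cc1cn(C/C=C\CN2C(=O)c3ccccc3C2=O)c(=O)[nH]c1=O` gives 68000 nM in a functional assay on MIA PaCa-2 cells (Homo sapiens) for antiproliferative activity, read by MTT assay, with a stated time of 3 days; a lower number here means a stronger inhibitor, a higher number a weaker inhibitor. Compound 3 `CCCCC#Cc1cn(C/C=C/CN2C(=O)c3ccccc3C2=O)c(=O)[nH]c1=O` gives 77000 nM. Compound 2 `CCCCCCCCC#Cc1cn(C/C=C/CN2C(=O)c3ccccc3C2=O)c(=O)[nH]c1=O` sits at a limit of this assay, > 100000 nM.

Compound 1 holds the lowest of the two numbers, with compound 3 within the scatter of it. The step to compound 4 `CCCCc1ccc(C#Cc2cn(C/C=C\CN3C(=O)c4ccccc4C3=O)c(=O)[nH]c2=O)cc1` is 4-butylphenyl in place of octyl on a triple-bonded carbon. Among the measured compounds shown here, no measured step alters that position; the known steps are an at least 1.4-fold higher number from compound 1 to compound 2 (0.16 log units; that floor lies within the scatter) and an at least 1.2-fold lower number from compound 2 to compound 3 (0.11 log units; that floor lies within the scatter), both within the scatter, and the limit of > 100000 nM in this assay, at which 1 of the 3 values shown sits, caps the first. The chain length change in the second step gives the only hint for the substituent on the triple bond, and it was small. Compound 4 is therefore expected near compound 1, with a 1.4-fold lower number from compound 1 to compound 4 (0.13 log units; within the scatter); its estimated value is 50000 nM, ranging from 15000 nM to 150000 nM.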

Compound 4, half-maximal inhibitory concentration: 56000 nM
Estimate against measurement, compound 4: 1.1-fold (0.05 log units) below; low and high end bracket the measured number.
By their numbers in this assay, from the lowest: compounds 4, 1 and 3 (each within the scatter of the next). At a limit, above all of these: compound 2.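

Placing 4-butylphenyl instead of octyl on the triple-bonded carbon gives a 1.2-fold lower number from compound 1 to compound 4 (0.08 log units; within the scatter) in this assay. The earlier compounds shown here varied only a chain at this position, whereas compound 4 shows that a six-membered aromatic ring of carbon only can stand there with the number staying within the scatter. Nothing shown accounts for this small step. Going by these compounds, it remains open whether an amine or a carboxylic acid on the triple-bonded carbon would move the number beyond the scatter. On these data alone, the E double bond paired with 4-butylphenyl also remains open.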